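The source may hold more compounds than are shown below. What is called first, only, known or untested is meant among the compounds shown, and "the series" means these compounds.

Measured so far in a physicochemical assay for solubility, in phosphate buffer, with a stated time of 24 h, at pH 7.4; a higher number here means a more soluble compound, a lower number a less soluble compound:
- compound 1 `COc1ccc(-c2ccc(OCc3cc(C(=O)NS(=O)(=O)c4ccccc4)oc3C)cc2)c(C)c1` gives 20 ug/mL
- compound 2 `COc1ccc(-c2ccc(OCc3cc(C(=O)NS(=O)(=O)c4ccc(CN)cc4)oc3C)cc2)cc1` gives < 0.6 ug/mL (a limit, not a number)
- compound 3 `CCCS(=O)(=O)NC(=O)c1cc(COc2ccc(-c3ccc(OC)cc3)cc2)c(C)o1` gives 7 ug/mL

Compound 3 holds the lower of the two actual numbers in this assay and sits under compound 1 by more than the scatter. The entry for compound 2 is only a limit.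

Next comes compound 4 `COc1ccc(-c2ccc(OCc3cc(C(=O)NS(=O)(=O)c4ccccc4)oc3C)cc2)cc1`, with the change phenyl in place of propyl on a sulfonyl sulfur.

Going by the values given here, one measured step touches this place: an at least 11-fold higher number from compound 2 to compound 3 (1.06 log units; beyond the scatter). It is large and beyond the scatter, but one end of it is a limit. It also concerns 4-(aminomethyl)phenyl rather than plain phenyl, so its size does not carry over directly. Among the compounds with values here, compound 1 also has phenyl on the sulfonyl sulfur and gives 20 ug/mL, which argues against a steep fall, although no measured step links it to compound 4. No step beyond the scatter is therefore expected in this assay, in either direction. The expected size is a 1.2-fold lower number from compound 3 to compound 4 (0.07 log units; within the scatter) with a wide margin. Compound 4 is estimated at 6 ug/mL, with an expected range from 1.5 ug/mL to 20 ug/mL.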

Compound 4, solubility: 11 ug/mL
Compound 4: middle estimate off by 1.8-fold (0.26 log units), on the low side, within the range that was stated.
By their numbers in this assay, from the lowest: compounds 3, 4 and 1 (each within the scatter of the next, the first and the last beyond it). At a limit, below all of these: compound 2.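

In this assay, going by these compounds alone, phenyl in place of propyl on a sulfonyl sulfur gives a 1.6-fold higher number from compound 3 to compound 4 (0.20 log units; within the scatter), the first step at this position with a number at both ends, and hydrogen in place of methyl on an aromatic carbon gives a 1.8-fold lower number from compound 1 to compound 4 (0.26 log units; within the scatter), so neither change separates its pair of compounds. Hydrogen in place of aminomethyl on an aromatic carbon gives an at least 18-fold higher number from compound 2 to compound 4 (1.26 log units; beyond the scatter), which shows that the large step seen earlier with propyl on the sulfonyl sulfur also appears with plain phenyl there, so it does not depend on propyl. The entry for compound 2 is a limit and not a number, so the true size of both of its steps stays unknown: the limit of < 0.6 ug/mL in this assay, at which 1 of the 4 values shown sits.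

Open, going by these compounds, is whether the large step is particular to aminomethyl, or whether a carboxylic acid or a tertiary amine in its place on the phenyl would read differently in this assay. Also open, on these data alone, is how a chain longer than propyl on the sulfonyl sulfur would compare with propyl and phenyl.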